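From (3-methoxyphenyl)amino to cyclohexylamino on the shared core

The source may hold more compounds than are shown below. What is called first, only, known or untested is meant among the compounds shown, and "the series" means these compounds.

In a functional assay on MGC-803 cells (Homo sapiens) for inhibition, read by sulforhodamine B assay (a higher number here means a weaker inhibitor, a lower number a stronger inhibitor), compound 1 (`O=C1C(Nc2ccccc2F)=CC(=O)c2c1nc1n2[C@H]2OC[C@@H](O)[C@H]2OC1`) gives 2000 nM and compound 2 (`COc1cccc(NC2=CC(=O)c3c(nc4n3[C@H]3OC[C@@H](O)[C@H]3OC4)C2=O)c1`) gives 1790 nM. For the measured compounds named here, these two values cannot be told apart, so compound 2 stands level with the only other measured compound.

Compound 3 (`O=C1C(NC2CCCCC2)=CC(=O)c2c1nc1n2[C@H]2OC[C@@H](O)[C@H]2OC1`) carries cyclohexyl in place of 3-methoxyphenyl on an amine nitrogen.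

Going by the values given here, only one measured step bears on this change: a 1.1-fold lower number from compound 1 to compound 2 (0.05 log units; within the scatter), with 3-methoxyphenyl in place of 2-fluorophenyl on an amine nitrogen. That step exchanged one aromatic ring for another, whereas here a non-aromatic ring enters. Among the compounds with values here, no measured compound has such a ring at this place, so the evidence is thin and the range must stay wide. No clear change beyond the scatter is expected, with a slight lean towards a weaker inhibitor. The expected step is a 1.6-fold higher number from compound 2 to compound 3 (0.19 log units; within the scatter). For compound 3, the estimated value in this assay is 2800 nM, with an expected range of 900 nM to 8000 nM.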

Compound 3, half-maximal inhibitory concentration: > 8000 nM
Compound 3 gave a limit, no number; the forecaster's own chance of this, stated with the estimate: 7%; at least 2.8-fold (0.45 log units) between middle value and limit.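

In this assay, on these data alone, compound 3 gives > 8000 nM, which is a limit of the assay and not a number, so its true value and the full size of its steps remain unknown: the limit of > 8000 nM in this assay, at which 1 of the 3 values shown sits. Even so, the steps to compound 3 are the first at this position that lie beyond the scatter: the change from 3-methoxyphenyl to cyclohexyl on the amine nitrogen gives an at least 4.4-fold higher number from compound 2 to compound 3 (0.65 log units; beyond the scatter), and the change from 2-fluorophenyl to cyclohexyl gives an at least 4.0-fold higher number from compound 1 to compound 3 (0.60 log units; beyond the scatter). The position therefore does respond to the group it carries, which the exchange of one aromatic ring for another did not show, and among these three compounds the two with an aromatic ring stand level while the single compound with a non-aromatic ring is the weaker, with none going against this, though one compound is thin support.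

As far as these compounds go, it remains open whether the aromatic ring itself matters or whether other groups on this nitrogen would also hold the activity, such as benzyl, a morpholine ring or a short open alkyl chain. Unsubstituted phenyl would show whether the fluorine and methoxy substituents contribute anything at all.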